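Aryl ether variation on the shared core: tert-butylphenyl analogue

A few compounds are considered here, and "the series" means these few. Any claim that something is new, unique, unknown or untested is made for them only; others in the source may bear on it.

Compound 2 `COc1cccc(Oc2ccc3cc(NC(=O)c4ccc(OC(C)=O)c(CC=C(C)C)c4)c(=O)oc3c2C)c1` is the compound with the lower of the two measured numbers in a functional assay on SK-BR-3 cells (Homo sapiens) for antiproliferative activity; on this read-out lower numbers stand for stronger inhibition and higher numbers for weaker inhibition; compound 2 gives 13700 nM. Its nearest measured neighbour is compound 1 `COc1ccc(Oc2ccc3cc(NC(=O)c4ccc(OC(C)=O)c(CC=C(C)C)c4)c(=O)oc3c2C)cc1`, which in this assay gives 19500 nM; the step of a 1.4-fold lower number from compound 1 to compound 2 (0.15 log units; within the scatter) is within the scatter, so the two cannot be ordered.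

Compound 3 `CC(=O)Oc1ccc(C(=O)Nc2cc3ccc(Oc4ccc(C(C)(C)C)cc4)c(C)c3oc2=O)cc1CC=C(C)C` is the next point in the series. Its difference from compound 2 is 4-(tert-butyl)phenyl in place of 3-methoxyphenyl on an oxygen on an aromatic ring. Going by the values given here, the only measured step, from compound 1 to compound 2, also changes the aryl group on this oxygen and stays within the scatter; no measured pair carries a 4-(tert-butyl)phenyl group, so there is no direct precedent. On that basis no step beyond the scatter is expected in this assay, with the estimated step being a 1.1-fold lower number from compound 2 to compound 3 (0.06 log units; within the scatter).

Compound 3 is therefore expected to give about 12000 nM in this assay, with a range of 4000 nM to 40000 nM.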

Compound 3, half-maximal inhibitory concentration: 72400 nM
Compound 3: the middle estimate sits 6.0-fold (0.78 log units) below what was measured; the whole stated range lies below it.
By their numbers in this assay, from the lowest: compounds 2 and 1 (each within the scatter of the next); then compound 3.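

Going by these compounds alone, the aryl group on this oxygen is not a silent position in this assay: 4-(tert-butyl)phenyl in place of 3-methoxyphenyl gives a 5.3-fold higher number from compound 2 to compound 3 (0.72 log units; beyond the scatter) and is the first step beyond the scatter, whereas the earlier change between the two methoxyphenyl groups could not be ordered. Tert-butyl in place of methoxy on an aromatic carbon points the same way, with a 3.7-fold higher number from compound 1 to compound 3 (0.57 log units; beyond the scatter) for a change in that one group alone, so compound 3 stands apart from both methoxyphenyl compounds. Nothing available on these compounds bears on the reason for these steps.

Going by these compounds, it remains open whether the higher number belongs to tert-butyl specifically or would also come with a smaller group such as methyl. Plain phenyl, 3-(tert-butyl)phenyl or an aryl group carrying an amine on this oxygen would help define how far the trend extends.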